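Amide variation on a cathepsin S cyclopentane scaffold

The source may hold more compounds than are shown below. What is called first, only, known or untested is meant among the compounds shown, and "the series" means these compounds.

Compound 1 `CC1CCN(C(=O)[C@@H]2C[C@H](S(=O)(=O)c3ccccc3)C[C@H]2C(=O)NC2(C#N)CC2)CC1` gives 0.5 nM in an assay on isolated protein for inhibition of cathepsin S (Homo sapiens), read by fluorescence, with a stated time of 20 min; on this read-out lower numbers stand for stronger inhibition and higher numbers for weaker inhibition.
Compound 2 `N#CC1(NC(=O)[C@@H]2C[C@@H](S(=O)(=O)c3ccccc3)C[C@H]2C(=O)N2CCS(=O)(=O)CC2)CC1` gives 4 nM in this assay.

Of the two measured compounds, compound 2 carries the higher number: the step of an 8.0-fold higher number from compound 1 to compound 2 (0.90 log units; beyond the scatter) shows that exchanging the amide substituent on the shared core moves the read-out beyond the scatter, though only modestly. Compound 3 `N#CC1(NC(=O)[C@@H]2C[C@@H](S(=O)(=O)c3ccccc3)C[C@H]2C(=O)N2CC(O)C2)CC1` keeps the core of compound 2 and differs from it in one place: 3-hydroxyazetidin-1-yl in place of 1,1-dioxothiomorpholin-4-yl on a carbonyl carbon. For the measured compounds named here, the only measured step that bears on this change is an 8.0-fold higher number from compound 1 to compound 2 (0.90 log units; beyond the scatter), which shows the amide group to be a position where an exchange can shift the number, but nothing measured separates a smaller ring from a larger one. Compound 3 is therefore expected to land near compound 2, with an expected step of no change at the digits printed from compound 2 to compound 3 (within the scatter) that could fall either way. The estimate for compound 3 is 4 nM, with a range from 1.2 nM to 14 nM.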

Compound 3, half-maximal inhibitory concentration: 7 nM
The estimate for compound 3 lay 1.8-fold (0.24 log units) below the measured number; measured number inside the range.
By their numbers in this assay, from the lowest: compound 1; then compounds 2 and 3 (each within the scatter of the next).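

With a 1.8-fold higher number from compound 2 to compound 3 (0.24 log units; within the scatter), the exchange of 1,1-dioxothiomorpholin-4-yl for the smaller 3-hydroxyazetidin-1-yl, which also brings a hydrogen-bond donor, does not separate these two compounds in this assay. So this position tolerates a change in ring size and in the hetero atoms on the carbonyl carbon without a step beyond the scatter. The larger difference remains the one from 4-methylpiperidin-1-yl, now seen a second time in a 14-fold higher number from compound 1 to compound 3 (1.15 log units; beyond the scatter), so compound 1 stands apart from both other amides, though nothing at hand gives a reason for this.

From the compounds shown here alone, it remains open whether an unsubstituted piperidin-1-yl or a morpholin-4-yl group would read like compound 1 or like compounds 2 and 3. Equally open, going by these compounds, is whether the methyl group of compound 1 matters, or whether an amine or a carboxylic acid on the ring would be tolerated here.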